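Triazole substituent variation and cytotoxicity on the shared core

The source may hold more compounds than are shown below. What is called first, only, known or untested is meant among the compounds shown, and "the series" means these compounds.

Compound 3 `COc1nc2ccc(Br)cc2cc1C(c1ccccc1)n1cc(CCCCCO)nn1` gives 7.96% in an ADME assay on HEK293 cells (Homo sapiens) for cytotoxicity, read by sulforhodamine B assay, with a stated time of 48 h, tested at 10 uM (a lower number here means less inhibition, a higher number more inhibition at the concentration tested (going by the name of the read-out)), and sits second highest of the three numbers shown, although its steps to both neighbours are within the scatter: compound 1 `COc1nc2ccc(Br)cc2cc1C(c1ccccc1)n1cc(-c2ccccc2)nn1` gives 8.25%, with a number 0.3 percentage points lower from compound 1 to compound 3 (within the scatter), and compound 2 `COc1nc2ccc(Br)cc2cc1C(c1ccccc1)n1cc(-c2ccccc2F)nn1` gives 3.97%, with a number 4 percentage points higher from compound 2 to compound 3 (within the scatter). Compound 4 `COc1nc2ccc(Br)cc2cc1C(c1ccccc1)n1cc(C2CC2)nn1` carries the change (cyclopropyl in place of 5-hydroxypentyl on an aromatic carbon). Among the compounds with values here, the measured steps at this position of the five-membered aromatic ring with 3 nitrogen, a number 4.3 percentage points lower from compound 1 to compound 2 (within the scatter) and a number 4 percentage points higher from compound 2 to compound 3 (within the scatter), all stay within the scatter, and no measured step involves cyclopropyl. No step beyond the scatter is therefore expected in this assay; the expected step is a number 1 percentage points lower from compound 3 to compound 4 (within the scatter). Compound 4 is estimated at 7%, with a range from 0% to 16%.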

Compound 4, a percentage reported as inhibition, at one concentration (the size of the read-out at that concentration, not a potency): 8.22%
Compound 4: middle estimate off by 1.2 percentage points, on the low side, within the range that was stated.
By their numbers in this assay, from the lowest: compounds 2, 3, 4 and 1 (each within the scatter of the next).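

In this assay cyclopropyl on this aromatic carbon reads the same as the 5-hydroxypentyl chain (a number 0.3 percentage points higher from compound 3 to compound 4 (within the scatter)), as 2-fluorophenyl (a number 4.3 percentage points higher from compound 2 to compound 4 (within the scatter)) and as phenyl (a number 0 percentage points lower from compound 1 to compound 4 (within the scatter)). A non-aromatic ring therefore joins aromatic rings and an open chain at this position, and losing the chain's hydrogen-bond donor and acceptor moves no step beyond the scatter. No evidence on the reason for this is available.

On these data alone, whether an amine, a carboxylic acid or a chain longer than 5-hydroxypentyl on this carbon would leave the scatter remains open.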